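Ring Swap on the Aromatic Carbon of Compound 1

The source may hold more compounds than are shown below. What is called first, only, known or untested is meant among the compounds shown, and "the series" means these compounds.

Compound 1 `Cc1c(Cl)cccc1Oc1cccn2c(C34CCC(CC3)C4)nnc12` is the reference point of this set. In an ADME assay on microsomes from liver (Homo sapiens) for metabolic stability, with a stated time of 10 min (a lower number here means that less of the compound is left, a higher number that more of the compound is left), compound 1 gives 69%, the lowest of the two numbers recorded. Its nearest neighbour is compound 2 `Cc1c(Cl)cccc1Oc1cccn2c(C3CCC(C)(O)CC3)nnc12`, which in this assay gives 99%. Compound 3 `Cc1c(Cl)cccc1Oc1cccn2c(C34CCC(N)(CC3)CC4)nnc12` in this assay gives "not determined" (no result reported), so no number exists for it.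

The step to compound 4 `Cc1c(Cl)cccc1Oc1cccn2c(C3CCCCCC3O)nnc12` alters the group on the aromatic carbon between two ring nitrogen atoms: a group of 8 heavy atoms (7 carbon, 1 oxygen; one seven-membered non-aromatic ring of carbon only) in place of a group of 7 heavy atoms (7 carbon; 2 five-membered non-aromatic rings of carbon only), on an aromatic carbon. For the measured compounds named here, one measured step bears on this. The change a number 30 percentage points higher from compound 1 to compound 2 (beyond the scatter) also removed the same bicyclic group in favour of a single non-aromatic carbon ring carrying a hydroxyl, and that step lay beyond the scatter. Compound 4 likewise brings a hydroxyl-bearing ring to this carbon, here as 2-hydroxycycloheptyl rather than the hydroxyl- and methyl-bearing six-membered ring seen in compound 2, so the analogy is close but not exact.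

An increase beyond the scatter is therefore expected, a number 19 percentage points higher from compound 1 to compound 4 (beyond the scatter), read as a somewhat smaller gain than the measured step, since the ring size and substitution differ. Compound 4 is estimated at 88% in this assay, with a range from 72% to 99%.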

Compound 4, percent of the compound remaining: 81%
Compound 4: the middle estimate sits 7 percentage points above what was measured; the measured number falls inside the stated range.
By their numbers in this assay, from the lowest: compound 1; then compound 4; then compound 2.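

In this assay the step reads a number 12 percentage points higher from compound 1 to compound 4 (beyond the scatter) and shows that, on this aromatic carbon of the five-membered aromatic ring, a gain over the group with 2 five-membered non-aromatic rings is not limited to 4-hydroxy-4-methylcyclohexyl; 2-hydroxycycloheptyl gives one as well. The two hydroxyl-bearing rings do not read alike, however: the change between them gives a number 18 percentage points lower from compound 2 to compound 4 (beyond the scatter) and so marks the ring that carries the hydroxyl as a variable in its own right, beyond the mere presence of a hydroxyl. No measurement at hand accounts for either step.

Ring size, the place of the hydroxyl and the extra methyl all change together between the two hydroxyl-bearing rings, so the compounds shown do not separate their contributions; a 4-hydroxycycloheptyl or an unmethylated 4-hydroxycyclohexyl group would bear on that. Also open, from the compounds shown here alone, is whether the gain survives on this carbon when the hydroxyl gives way to a methyl ether or a carboxylic acid on the same ring.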